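The source may report more compounds than this note shows. Statements on the series, on what has been measured and on what is new or still open speak of the compounds shown alone.

Measured compounds:
compound 1 `COc1cc2nccc(O)c2c(O)c1OC` — > 40000 nM
compound 2 `COc1cc2c(c(OC)c1OC)c(=O)ccn2C` — > 40000 nM
compound 3 `COc1cc(OC)c2c(=O)ccn(C)c2c1` — > 40000 nM

In a functional assay on L1210 cells (Mus musculus) for antiproliferative activity (on this read-out higher numbers stand for weaker inhibition and lower numbers for stronger inhibition), compound 1 gives > 40000 nM, which is a limit of the assay and not a number. In this assay compound 2 gives > 40000 nM, again a limit. In this assay compound 3 gives > 40000 nM, also a limit. The difference between the core of compound 1 and the core of compound 2 is not broken down here. From compound 2 to compound 3 the change is hydrogen in place of methoxy on an aromatic carbon, and the step is a step that the two limits leave unreadable from compound 2 to compound 3. Compound 4 `COc1cc(O)c2c(O)ccnc2c1` is not yet measured. It differs from compound 1 by hydrogen in place of methoxy on an aromatic carbon; this is the same kind of change as that from compound 2 to compound 3, though here the place is ortho to a hydroxy group and ortho to a methoxy group rather than ortho to two methoxy groups. Because (the limit of > 40000 nM in this assay, at which 3 of the 3 values shown sit), the measured step gives no size to carry over. Resting on compound 1 and on (the limit of > 40000 nM in this assay, at which 3 of the 3 values shown sit), the step is expected as a step that the limit leaves unreadable from compound 1 to compound 4. Compound 4 is estimated at 60000 nM, between 20000 nM and 200000 nM, and is most likely to be reported only as a limit.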

Compound 4, half-maximal inhibitory concentration: > 40000 nM
Compound 4 was reported as a limit; the forecaster's own chance of this, stated with the estimate: 85%; the middle value is on the limit's open side.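

No new step can be read between compound 1 and compound 4, as both stand only as limits: the limit of > 40000 nM in this assay, at which 4 of the 4 values shown sit.

In this assay the compounds shown leave open the size of any effect of hydrogen in place of methoxy on an aromatic carbon.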